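The source may report more compounds than this note shows. Statements on the series, on what has been measured and on what is new or still open speak of the compounds shown alone.

Of the compounds shown here, three sharing one core have been measured in a functional assay on A549 cells (Homo sapiens) for antiproliferative activity, read by MTT assay, with a stated time of 72 h; a higher number here means a weaker inhibitor, a lower number a stronger inhibitor. Compound 1 `COc1cc(-n2cnc3ccc(-c4ccc([N+](=O)[O-])cc4)cc32)cc(OC)c1OC` gives 8940 nM in this assay, compound 2 `COc1cc(-n2cnc3ccc(-c4cccc(C)c4C)cc32)cc(OC)c1OC` gives 9250 nM, and compound 3 `COc1cc(-n2cnc3ccc(-c4cccc(C)c4)cc32)cc(OC)c1OC` gives 3820 nM, the lowest of the three numbers. The step of a 2.3-fold lower number from compound 1 to compound 3 (0.37 log units; beyond the scatter) and the step of a 2.4-fold lower number from compound 2 to compound 3 (0.38 log units; beyond the scatter) both exchanged the group on the aromatic carbon and gave modest, lower numbers, while the step of a 1.0-fold higher number from compound 1 to compound 2 (0.01 log units; within the scatter) stayed within the scatter. Compound 4 `COc1cc(-n2cnc3ccc(-c4ccc(O)cc4)cc32)cc(OC)c1OC` differs from compound 3 by 4-hydroxyphenyl in place of 3-methylphenyl on an aromatic carbon. Among the measured compounds shown here, none of the measured steps brings a hydrogen-bond donor into this place. The change is expected to give only a small step in this assay, most likely toward a higher number: a 1.6-fold higher number from compound 3 to compound 4 (0.20 log units; within the scatter). Compound 4 is therefore estimated at 6000 nM, within 2500 nM to 15000 nM.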

Compound 4, half-maximal inhibitory concentration: 5090 nM
Estimate against measurement, compound 4: 1.2-fold (0.07 log units) above; the range from low to high includes it.
By their numbers in this assay, from the lowest: compounds 3, 4, 1 and 2 (each within the scatter of the next, the first and the last beyond it).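

In this assay, among the compounds shown here, a hydrogen-bond donor enters this place for the first time, yet a 1.3-fold higher number from compound 3 to compound 4 (0.12 log units; within the scatter) stays within the scatter. The same holds against the two other groups, with a 1.8-fold lower number from compound 2 to compound 4 (0.26 log units; within the scatter) and a 1.8-fold lower number from compound 1 to compound 4 (0.24 log units; within the scatter), so 4-hydroxyphenyl cannot be told apart from any earlier group here, and the hydroxy group neither clearly helps nor clearly harms. Nothing measured here offers an explanation for this result. Still open, on these data alone, is what an amine or a carboxylic acid on the same phenyl ring would give, and whether a longer chain bearing the hydroxy group would read differently.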